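Removing the Hydroxy Group from Compound 1

The source may hold more compounds than are shown below. What is called first, only, known or untested is meant among the compounds shown, and "the series" means these compounds.

Measured so far:
compound 1, `O=C(COc1cccc2ccccc12)N/N=C/c1ccc(O)cc1`, 60.6 ug/mL
compound 2, `COc1ccc(/C=N/NC(=O)COc2cccc3ccccc23)cc1OC`, 52.6 ug/mL
compound 3, `C/C(=N\NC(=O)COc1cccc2ccccc12)c1ccccc1O`, 4 ug/mL

In an ADME assay on HEL cells (Homo sapiens) for cytotoxicity (on this read-out lower numbers stand for higher toxicity in this test and higher numbers for lower toxicity in this test), compound 1 gives 60.6 ug/mL, the highest of the three numbers. Compound 2 gives 52.6 ug/mL, which lies within the scatter of that value, so the two cannot be told apart. Compound 3 gives 4 ug/mL, a far lower number that sits well beyond the scatter. Compound 4, `O=C(COc1cccc2ccccc12)N/N=C/c1ccccc1`, has not been measured yet. It differs from compound 1 by hydrogen in place of hydroxy on an aromatic carbon. Among the compounds with values here, no pair among the measured compounds shows what this change does in this assay. A step no larger than the scatter is expected, namely a 1.3-fold lower number from compound 1 to compound 4 (0.13 log units; within the scatter). Compound 4 is therefore estimated to give 45 ug/mL, between 20 ug/mL and 100 ug/mL.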

Compound 4, half-maximal cytotoxic concentration: 64.5 ug/mL
For compound 4 the middle estimate is 1.4-fold (0.16 log units) below the measured one; the measured number falls inside the stated range.
By their numbers in this assay, from the lowest: compound 3; then compounds 2, 1 and 4 (each within the scatter of the next).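

In this assay, within the data shown here, putting hydrogen in place of hydroxy on this aromatic carbon amounts to a 1.1-fold higher number from compound 1 to compound 4 (0.03 log units; within the scatter), the first direct reading of this change. At this place, going from 4-hydroxyphenyl to phenyl leaves the number indistinguishable, so the hydroxy group is not needed to keep it where it stands in this test. No measurement at hand explains this result. Open, on these data alone, is whether an amine or a carboxylic acid at the same place would also leave the number unchanged. Also open, as far as these compounds go, is whether removing the hydroxy group from compound 3 would matter more.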